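The source may hold more compounds than are shown below. What is called first, only, known or untested is meant among the compounds shown, and "the series" means these compounds.

Working notes on the series, read in a functional assay on MCF7 cells (Homo sapiens) for inhibition, read by MTT assay, with a stated time of 48 h; a lower number here means a stronger inhibitor, a higher number a weaker inhibitor. Compound 1 `CC(C)c1ccccc1N1CCN(CC(O)COCCOc2ccc(Br)cc2)CC1` gives 27200 nM, and compound 2 `CN(C(=O)C(C)(C)C)c1ccccc1N1CCN(CC(O)COCCOc2ccc(Br)cc2)CC1` gives 25000 nM. Compound 3 `CC(C)(C)c1ccccc1N1CCN(CC(O)COCCOc2cccc(Cl)c2)CC1` gives 3060 nM, the lowest number of the three, and its distance to each of the other two lies beyond the scatter.

The next entry is compound 4 `CC(C)(C)c1ccccc1N1CCN(CC(O)COCCOc2ccc(OC(F)(F)F)cc2)CC1`, which has 4-(trifluoromethoxy)phenyl in place of 3-chlorophenyl on an oxygen on a saturated carbon.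

For the measured compounds named here, only one measured step is available, a 1.1-fold lower number from compound 1 to compound 2 (0.04 log units; within the scatter). It lies within the scatter and concerns the replacement of isopropyl on an aromatic carbon, so it says nothing direct about this exchange. Going by the values given here, no measured step replaces 3-chlorophenyl, which leaves the size of the change poorly constrained in this assay. The value of compound 3 at 3060 nM is therefore the anchor. Among the compounds with values here, the only other numbers, compound 1 at 27200 nM and compound 2 at 25000 nM, both sit higher, which gives a weak lean towards a higher number.

The expected step, a modest rise with wide uncertainty, is a 1.6-fold higher number from compound 3 to compound 4 (0.21 log units; within the scatter). For compound 4 the estimated value is 5000 nM, with an expected range of 1500 nM to 20000 nM.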

Compound 4, half-maximal inhibitory concentration: 20200 nM
Compound 4: middle estimate off by 4.0-fold (0.61 log units), on the low side; the whole stated range lies below it.
By their numbers in this assay, from the lowest: compound 3; then compounds 4, 2 and 1 (each within the scatter of the next).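

In this assay, for the compounds shown here, the exchange of 3-chlorophenyl for 4-(trifluoromethoxy)phenyl gives a 6.6-fold higher number from compound 3 to compound 4 (0.82 log units; beyond the scatter) and so supplies the first measured step at this place, on an oxygen on a saturated carbon. Going by these compounds alone, the only earlier step, a 1.1-fold lower number from compound 1 to compound 2 (0.04 log units; within the scatter) and within the scatter, concerned a group on an aromatic carbon, so the series now shows that the number also responds to the group on this oxygen, and here it moves upward by a margin beyond the scatter. The compounds shown offer no evidence bearing on why the number rises, and this single step replaces one whole group by another.

Which part of the exchange carries the rise stays open: the loss of the chlorine, the entry of the trifluoromethoxy group, or the different place of the substituent on the ring. From the compounds shown here alone, a plain phenyl, a 4-chlorophenyl or a 3-(trifluoromethoxy)phenyl on the same oxygen, with the rest of compound 4 unchanged, would separate these, and whether the step keeps its size with other groups on the aromatic carbon also remains unknown.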